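A few compounds are considered here, and "the series" means these few. Any claim that something is new, unique, unknown or untested is made for them only; others in the source may bear on it.

Compound 1 `COc1ccc(S(=O)(=O)Nc2cccc(Br)c2)cc1N1CCNCC1` gives 1.26 nM in an assay on isolated protein for binding affinity to 5-hydroxytryptamine receptor 6 (Homo sapiens); on this read-out higher numbers stand for weaker inhibition and lower numbers for stronger inhibition.
Compound 2 `COc1ccc(Cl)cc1NS(=O)(=O)c1ccc(OC)c(N2CCNCC2)c1` gives 1.26 nM in this assay.
Compound 3 `COc1ccc(S(=O)(=O)Nc2ccc(Cl)c(Cl)c2)cc1N1CCNCC1` gives 2.51 nM in this assay.

Compound 3 has the highest number of the three, but its gaps to both neighbours stay within the scatter: a 2.0-fold higher number from compound 1 to compound 3 (0.30 log units; within the scatter) and a 2.0-fold higher number from compound 2 to compound 3 (0.30 log units; within the scatter). Compound 4 `COc1ccc(S(=O)(=O)Nc2cc(F)cc(F)c2Cl)cc1N1CCNCC1` changes the same place again: 2-chloro-3,5-difluorophenyl in place of 3,4-dichlorophenyl on a sulfonamide nitrogen. Both earlier exchanges of the group on the sulfonamide nitrogen left this assay essentially untouched, and compound 1 and compound 2 sit together within the scatter, so a fresh halogenated phenyl there is expected to move the number little. The step is therefore estimated as a 1.0-fold lower number from compound 3 to compound 4 (0.00 log units; within the scatter), no direction beyond the scatter. Compound 4 is expected to give about 2.5 nM, within a range from 1 nM to 8 nM.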

Compound 4, inhibition constant: 31.6 nM
The estimate for compound 4 lay 13-fold (1.10 log units) below the measured number, outside the stated range (above it).
By their numbers in this assay, from the lowest: compounds 1, 2 and 3 (each within the scatter of the next); then compound 4.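

Among these compounds, the group on the sulfonamide nitrogen turns out not to be indifferent: in this assay the exchange to 2-chloro-3,5-difluorophenyl from 3,4-dichlorophenyl gives a 13-fold higher number from compound 3 to compound 4 (1.10 log units; beyond the scatter) and is the first step here beyond the scatter. The same group gives a 25-fold higher number from compound 2 to compound 4 (1.40 log units; beyond the scatter) against 5-chloro-2-methoxyphenyl and a 25-fold higher number from compound 1 to compound 4 (1.40 log units; beyond the scatter) against 3-bromophenyl, so this position can move the number strongly although the three earlier groups stayed within the scatter of one another. Nothing available explains the rise.

The compounds shown do not separate the chlorine of 2-chloro-3,5-difluorophenyl from its fluorines. Going by these compounds, how an unsubstituted phenyl or a cyclohexyl group would read at this position stays open.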